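This account rests on a few compounds, and the source may have more. Where it says the series, first, only, none or still open, it means among the compounds named here.

Of the compounds shown here, three built on a shared core have been measured in a functional assay (aorta) with Rattus norvegicus as the target; a lower number here means a stronger inhibitor, a higher number a weaker inhibitor. Compound 1 `CCOC(=O)CCN(c1ccccc1)[C@H]1c2cc(C#N)ccc2OC(C)(C)[C@@H]1O` gives 54000 nM, compound 2 `CCCCOC(=O)CN(c1ccccc1)[C@H]1c2cc(C#N)ccc2OC(C)(C)[C@@H]1O` gives 27000 nM, and compound 3 `CC1(C)Oc2ccc(C#N)cc2[C@H](N(Cc2ccco2)c2ccccc2)[C@H]1O` gives 12000 nM. Compound 3 stands lowest of the three numbers: a 4.5-fold lower number from compound 1 to compound 3 (0.65 log units; beyond the scatter) and a 2.3-fold lower number from compound 2 to compound 3 (0.35 log units; beyond the scatter), whereas a 2.0-fold lower number from compound 1 to compound 2 (0.30 log units; within the scatter). Compound 4 `Cc1cc(CN(c2ccccc2)[C@H]2c3cc(C#N)ccc3OC(C)(C)[C@@H]2O)on1` differs from compound 3 in one place: 3-methyl-1,2-oxazol-5-yl in place of furan-2-yl on a saturated chain carbon bound to a nitrogen on an aromatic ring. Going by the values given here, none of the measured steps covers this kind of exchange. They all concern the replacement of (ethoxycarbonyl)methyl or butoxycarbonyl by furan-2-yl on a saturated chain carbon bound to a nitrogen on an aromatic ring, and those brought the modest gains that end at compound 3. Among the compounds with values here, an exchange of one five-membered aromatic ring for another at that place has no measured counterpart, so no step beyond the scatter is expected in this assay in either direction. Compound 4 is therefore estimated at 12000 nM, with a range of 5000 nM to 30000 nM, which corresponds to an expected step of no change at the digits printed from compound 3 to compound 4 (within the scatter).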

Compound 4, half-maximal inhibitory concentration: > 30000 nM
Compound 4 gave a limit, no number; the forecaster's own chance of this, stated with the estimate: 5%; middle value at least 2.5-fold (0.39 log units) from the limit.
By their numbers in this assay, from the lowest: compound 3; then compounds 2 and 1 (each within the scatter of the next).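

In this assay, compound 4 carries a limit and not a number: the limit of > 30000 nM in this assay, at which 1 of the 4 values shown sits. Even so, the exchange of one five-membered aromatic ring for another on a saturated chain carbon bound to a nitrogen on an aromatic ring proves not to be neutral, and the result reads as an at least 2.5-fold higher number from compound 3 to compound 4 (0.39 log units; beyond the scatter), the first step beyond the scatter at this place to run upward, so furan-2-yl is not freely exchangeable here. The comparison with butoxycarbonyl shows less, as an at least 1.1-fold higher number from compound 2 to compound 4 (0.04 log units; that floor lies within the scatter), and the step involving compound 1 cannot be read.

The compounds shown leave open whether the rise follows the added methyl or the ring nitrogen of 3-methyl-1,2-oxazol-5-yl. Also open, going by these compounds, is how an unsubstituted 1,2-oxazol-5-yl or a thiophen-2-yl would read at this place.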